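Swapping amino for ethoxy at one aromatic position

This account rests on a few compounds, and the source may have more. Where it says the series, first, only, none or still open, it means among the compounds named here.

Among the compounds with values here, in a functional assay on HepG2 cells (Homo sapiens) for antiproliferative activity, read by MTT assay, with a stated time of 48 h (on this read-out lower numbers stand for stronger inhibition and higher numbers for weaker inhibition), compound 1 (`COc1ccc(/C=C/c2cc(OC)cc(OC)c2/C=C/C(=O)c2ccc(Cl)c(Cl)c2)cc1`) gives 10.8 ug/mL and compound 2 (`COc1ccc(/C=C/c2cc(OC)cc(OC)c2/C=C/C(=O)c2ccc(N)cc2)cc1`) gives 7.5 ug/mL, so compound 2 stands within the scatter of the only other measured value. Compound 3 (`CCOc1ccc(C(=O)/C=C/c2c(/C=C/c3ccc(OC)cc3)cc(OC)cc2OC)cc1`) differs from compound 2 by ethoxy in place of amino on an aromatic carbon, with ethoxy in place of amino on an aromatic carbon, para to a large group. Within the data shown here, the one measured step, a 1.4-fold lower number from compound 1 to compound 2 (0.16 log units; within the scatter), changes the same aromatic group and stays within the scatter, so no step beyond the scatter is expected here. The expected change is a 1.2-fold higher number from compound 2 to compound 3 (0.08 log units; within the scatter). For compound 3 the estimated value is 9 ug/mL, with an expected range of 4.5 ug/mL to 18 ug/mL.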

Compound 3, half-maximal inhibitory concentration: 8 ug/mL
Beside the measured number, compound 3's estimate is 1.1-fold (0.05 log units) above it; measured number inside the range.
By their numbers in this assay, from the lowest: compounds 2, 3 and 1 (each within the scatter of the next).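

In this assay, ethoxy in place of amino on this aromatic carbon, para to a large group, gives a 1.1-fold higher number from compound 2 to compound 3 (0.03 log units; within the scatter), so exchanging the amino group's hydrogen-bond donor for the larger ethoxy leaves no readable change. Against the 3,4-dichlorophenyl group, 4-ethoxyphenyl gives a 1.4-fold lower number from compound 1 to compound 3 (0.13 log units; within the scatter), so these three aromatic groups on the carbonyl cannot be told apart here. No available evidence bears on this result.

As far as these compounds go, whether a carboxylic acid or a longer alkoxy chain at this position would move the number beyond the scatter remains open.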